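Hydroxy in Place of Iodo on the Aromatic Ring

The source may report more compounds than this note shows. Statements on the series, on what has been measured and on what is new or still open speak of the compounds shown alone.

Compound 2 `O=C(CCCCCc1cccc(I)c1)N1CCOC1=O` has been measured in an assay on HEK293 cells for inhibition of N-acylethanolamine-hydrolyzing acid amidase (Rattus norvegicus), read by LC-MS, with a stated time of 30 min (on this read-out higher numbers stand for weaker inhibition and lower numbers for stronger inhibition), where compound 2 gives 3120 nM. Of the two numbers in hand this is the higher one; its nearest neighbour is compound 1 `O=C(CCCCCc1ccc(F)c(Cl)c1)N1CCOC1=O`, which in this assay gives 26 nM. Compound 3 `O=C(CCCCCc1ccc(O)c(Cl)c1)N1CCOC1=O` is reported in this assay only as a limit, > 20000 nM. Among the compounds with values here, the one measured step that bears on the present question is an at least 760-fold higher number from compound 1 to compound 3 (2.88 log units; beyond the scatter), a step that runs into (the limit of > 20000 nM in this assay, at which 1 of the 3 values shown sits).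

The compound still to be measured, compound 4 `O=C(CCCCCc1cccc(O)c1)N1CCOC1=O`, differs from compound 2 by hydroxy in place of iodo on an aromatic carbon. In the measured step a halogen on an aromatic carbon also gave way to a hydroxy group, and the number rose sharply, to the point where only a limit was read. Compound 2 already starts from a high number, so a rise of similar kind in this assay would very likely carry compound 4 past what the assay can resolve. Compound 4 is therefore expected to give about 40000 nM in this assay, with a range from 8000 nM to 200000 nM. The expected step is a 13-fold higher number from compound 2 to compound 4 (1.11 log units; beyond the scatter), and a limit rather than a number is the more probable report.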

Compound 4, half-maximal inhibitory concentration: 8640 nM
For compound 4 the middle estimate is 4.6-fold (0.67 log units) above the measured one; the range from low to high includes it.
By their numbers in this assay, from the lowest: compound 1; then compound 2; then compound 4. At a limit, above all of these: compound 3.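

On an aromatic carbon meta to a large group, the change from iodo to hydroxy gives a 2.8-fold higher number from compound 2 to compound 4 (0.44 log units; beyond the scatter), a modest step that lies beyond the scatter yet still ends on a number: in this assay compound 4 gives 8640 nM. Hydroxy in place of a halogen on the aromatic ring therefore does not always reach the limit of the assay, as a record holding only an at least 760-fold higher number from compound 1 to compound 3 (2.88 log units; beyond the scatter) might have suggested. Compound 3 remains the only compound shown that is reported as a limit and not as a number: the limit of > 20000 nM in this assay, at which 1 of the 4 values shown sits.

The compounds shown leave open how an amine, a methoxy group or a carboxylic acid would read at this same position, and how fluoro or chloro would compare there with iodo and hydroxy. They also do not tell why this change costs so much less than the change from fluoro to hydroxy, since the two steps start from different compounds and one of them ends at a limit.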